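Dropping One Cyclohexyl From a Dihydropyridine Diester

The compounds below may be only part of what the source reports. "The series", "measured", "known", "first", "only" and "open" are said of these compounds alone.

In an assay on isolated protein for inhibition of Voltage-dependent L-type calcium channel subunit alpha-1C (Cavia porcellus) (on this read-out lower numbers stand for stronger inhibition and higher numbers for weaker inhibition), compound 2 `CC1=C(C(=O)OCC2CCCCC2)C(c2[nH]cnc2Cl)C(C(=O)OCC2CCCCC2)=C(C)N1` gives 631 nM. Its nearest companion, compound 1 `CC1=C(C(=O)OC2CCCCC2)C(c2[nH]cnc2Cl)C(C(=O)OC2CCCCC2)=C(C)N1`, gives 955 nM in this assay, and the two values lie within the usual scatter of each other, so neither can be ranked against the other. Compound 3 `COC(=O)C1=C(C)NC(C)=C(C(=O)OCC2CCCCC2)C1c1[nH]cnc1Cl` differs from compound 2 by hydrogen in place of cyclohexyl on a saturated chain carbon bound to an oxygen next to a carbonyl group. Within the data shown here, no step between measured compounds shows the effect of this change. Compound 3 is expected to give 1500 nM in this assay, within a range from 500 nM to 5000 nM, which means an expected weakening step a 2.4-fold higher number from compound 2 to compound 3 (0.38 log units; beyond the scatter) that is only slightly beyond the scatter.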

Compound 3, half-maximal inhibitory concentration: 355 nM
For compound 3 the middle estimate is 4.2-fold (0.63 log units) above the measured one; the measured number lies below the stated range.
By their numbers in this assay, from the lowest: compounds 3, 2 and 1 (each within the scatter of the next, the first and the last beyond it).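

Replacing cyclohexylmethoxycarbonyl with methoxycarbonyl on one side gives a 1.8-fold lower number from compound 2 to compound 3 (0.25 log units; within the scatter) in this assay, so the two compounds cannot be ranked. At this position, then, the cyclohexyl ring on that ester can go without a loss that this assay can resolve, and a small methyl ester serves as well as the large group here. As far as these compounds go, what remains open is whether a longer chain or a carboxylic acid at this place would read the same, and whether the other ester accepts the same change. No supporting data here bear on the reason for this result.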